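From chloro to methoxy on a shared core

A few compounds are considered here, and "the series" means these few. Any claim that something is new, unique, unknown or untested is made for them only; others in the source may bear on it.

Measured in a functional assay on KB cells (Homo sapiens) for cytotoxicity (a lower number here means that less compound is needed, a higher number that more compound is needed for the effect), so far:
- compound 1 `c1ccc(COc2cc(-c3ccccc3)nc3ccccc23)cc1` gives 1.6 ug/mL
- compound 2 `Oc1ccc2nc(-c3ccccc3)cc(O)c2c1` gives 0.41 ug/mL
- compound 3 `Oc1cc(-c2ccccc2)nc2ccc(Cl)cc12` gives 0.49 ug/mL

Among these three, compound 3 sits with compound 2, the two lying within the scatter of each other. Compound 1 stands apart from compound 3, with a higher number beyond the scatter.

The next compound, compound 4 `COc1ccc2nc(-c3ccccc3)cc(O)c2c1`, has not yet been measured. It carries methoxy in place of chloro on an aromatic carbon and is otherwise the same as compound 3.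

Within the data shown here, the one measured step at this place on the core is a 1.2-fold higher number from compound 2 to compound 3 (0.08 log units; within the scatter) for chloro in place of hydroxy on an aromatic carbon. Among the measured compounds shown here, no measured compound shows what methoxy itself does, so this single step is a limited guide. With a 1.2-fold higher number from compound 2 to compound 3 (0.08 log units; within the scatter) as that guide, no step beyond the scatter is expected in this assay for the exchange of chloro for methoxy, and no direction can be favoured. The estimated outcome is a 1.0-fold higher number from compound 3 to compound 4 (0.01 log units; within the scatter) as the expected step. Compound 4 is thus expected at 0.5 ug/mL with 0.2 ug/mL to 1.3 ug/mL as its estimated range.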

Compound 4, half-maximal effective concentration: 0.08 ug/mL
The estimate for compound 4 lay 6.3-fold (0.80 log units) above the measured number; the whole stated range lies above it.
By their numbers in this assay, from the lowest: compound 4; then compounds 2 and 3 (each within the scatter of the next); then compound 1.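

In this assay, the exchange of chloro for methoxy on this aromatic carbon gives a 6.1-fold lower number from compound 3 to compound 4 (0.79 log units; beyond the scatter). The position therefore responds to the group it carries, which the only earlier step here, hydroxy to chloro (a 1.2-fold higher number from compound 2 to compound 3 (0.08 log units; within the scatter)), had not shown. The oxygen alone does not account for the result, since compound 2 also has an oxygen at this place, and methyl in place of hydrogen on that oxygen gives a 5.1-fold lower number from compound 2 to compound 4 (0.71 log units; beyond the scatter); among these three compounds, only the methoxy compound stands apart, while the hydroxy and chloro compounds stay within the scatter of each other. Nothing at hand explains why methoxy differs from the other two groups.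

The compounds shown leave open whether this step is particular to methoxy or extends to an ethoxy group or a longer chain on the same oxygen. They also do not show how an amine or a carboxylic acid on this carbon would compare, or whether the hydroxy group elsewhere on the shared core is needed for the lower number of compound 4.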